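The compounds below may be only part of what the source reports. "The series", "measured", "known", "first", "only" and "open" are said of these compounds alone.

Compound 3 `O=C(C(Nc1ccccc1F)c1ccc(Br)cc1)N1CCC[C@H]1c1ccccc1F`: 9 nM
Compound 1 `O=C(C(Nc1ccccc1F)c1ccc(C(F)(F)F)cc1)N1CCCC1c1ccccc1Cl`: 11 nM
Compound 2 `O=C(C(Nc1ccccc1F)c1ccc(C(F)(F)F)cc1)N1CCCC1c1ccncc1`: 19 nM

Of the compounds shown here, three have been measured in an assay on HEK293 cells for antagonist activity at transient receptor potential M8 protein (Canis lupus familiaris), read by fluorescence and calcium flux, with a stated time of 5 min; a higher number here means a weaker inhibitor, a lower number a stronger inhibitor. Compound 3 gives the lowest number of the three, but its gap to compound 1 is within the scatter; only its gap to compound 2 lies beyond it. Compound 4 `O=C(C(Nc1ccccc1F)c1cc2ccccc2s1)N1CCC[C@H]1c1ccccc1F` has not yet been measured. It keeps everything of compound 3 except one group: 1-benzothiophen-2-yl in place of 4-bromophenyl on a saturated chain carbon bound to a carbonyl carbon and a nitrogen on an aromatic ring. Going by the values given here, the one measured step, a 1.7-fold higher number from compound 1 to compound 2 (0.24 log units; within the scatter), concerns a different place in the molecule, the saturated ring carbon, and was within the scatter; it says nothing about a swap on the chain carbon. Compounds 1 and 3 differ in two places at once, so their two values show only that both lie close together. No measured comparison therefore bears on the change to compound 4. With no guide in either direction, the expected step is a 1.3-fold higher number from compound 3 to compound 4 (0.12 log units; within the scatter), small and uncertain in sign, in this assay. Compound 4 is estimated at 12 nM, between 4 nM and 40 nM.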

Compound 4, half-maximal inhibitory concentration: 3 nM
For compound 4 the middle estimate is 4.0-fold (0.60 log units) above the measured one, and the stated range ends above it.
By their numbers in this assay, from the lowest: compound 4; then compounds 3, 1 and 2 (each within the scatter of the next, the first and the last beyond it).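

In this assay, going by these compounds alone, the saturated chain carbon bound to a carbonyl carbon and a nitrogen on an aromatic ring gives the first single-place change here that lies beyond the scatter: putting 1-benzothiophen-2-yl in place of 4-bromophenyl gives a 3.0-fold lower number from compound 3 to compound 4 (0.48 log units; beyond the scatter). This position therefore responds to the group it carries, and a group with two aromatic rings and a sulfur atom gives a stronger inhibitor than the single brominated ring. The swap changes the ring count, adds sulfur and removes bromine all at once, and no supporting measurement says why the number falls.

As far as these compounds go, it remains open whether the second ring or the sulfur atom matters more: a naphthyl group would have two rings without sulfur, and a benzofuranyl group would have oxygen in its place. From the compounds shown here alone, how this carbon responds to a group bearing an amine or a carboxylic acid is also open.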